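Shortening and Branching the Amide Chain on a Shared Core

The source may hold more compounds than are shown below. What is called first, only, known or untested is meant among the compounds shown, and "the series" means these compounds.

Compound 1 `CCCC(=O)Nc1ccc(S(=O)(=O)Oc2ccccc2C(C)C)cc1`: in a functional assay on M21 cells (Homo sapiens) for antiproliferative activity, read by sulforhodamine B assay, with a stated time of 48 h (a higher number here means a weaker inhibitor, a lower number a stronger inhibitor), compound 1 gives 6100 nM.
Compound 2 `CCCCCC(=O)Nc1ccc(S(=O)(=O)Oc2ccccc2C(C)C)cc1`: in this assay compound 2 gives 6700 nM.

Of the two numbers compound 2 holds the larger, but the difference, a 1.1-fold higher number from compound 1 to compound 2 (0.04 log units; within the scatter), is within the scatter. Compound 3 `CC(C)C(=O)Nc1ccc(S(=O)(=O)Oc2ccccc2C(C)C)cc1` differs from compound 2 by isopropyl in place of pentyl on a carbonyl carbon. Within the data shown here, the only step that bears on this, a 1.1-fold higher number from compound 1 to compound 2 (0.04 log units; within the scatter), altered the same chain without effect beyond the scatter, so in this assay no step beyond the scatter is expected. Compound 3 is therefore estimated at 6500 nM, ranging from 3000 nM to 14000 nM, an expected step of a 1.0-fold lower number from compound 2 to compound 3 (0.01 log units; within the scatter).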

Compound 3, half-maximal inhibitory concentration: 11000 nM
For compound 3 the middle estimate is 1.7-fold (0.23 log units) below the measured one, within the range that was stated.
By their numbers in this assay, from the lowest: compounds 1, 2 and 3 (each within the scatter of the next).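

Isopropyl on a carbonyl carbon is the first branched group here, and it gives a 1.6-fold higher number from compound 2 to compound 3 (0.22 log units; within the scatter) and a 1.8-fold higher number from compound 1 to compound 3 (0.26 log units; within the scatter) against the two straight chains. In this assay, branching at this position therefore shifts the number no further than the scatter, as lengthening the chain did, so all three compounds remain indistinguishable. Nothing available here offers an explanation for this.

From the compounds shown here alone, it remains open whether any group on this carbonyl carbon can move the number beyond the scatter. A phenyl ring, an amine or a carboxylic acid in place of isopropyl would test this.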